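The source may report more compounds than this note shows. Statements on the series, on what has been measured and on what is new or still open speak of the compounds shown alone.

Compounds measured in a functional assay on MDA-MB-231 cells (Homo sapiens) for inhibition, read by sulforhodamine B assay, with a stated time of 72 h; on this read-out lower numbers stand for stronger inhibition of growth and higher numbers for weaker inhibition of growth:

compound 1 `CN1CCN(C(=O)/C=C/c2ccncc2-c2ccc3ccccc3c2)CC1` — > 10000 nM
compound 2 `CCOC(=O)/C=C/c1ccncc1-c1ccc2c(cnn2C)c1` — > 10000 nM
compound 3 `O=C(/C=C/c1ccncc1-c1ccc2cc[nH]c2c1)N1CCOCC1` — > 10000 nM

Compound 1 gives only a limit of this assay, not a number. Compound 2 likewise sits at a limit of this assay. Compound 3 also gives a limit of this assay. For the measured compounds named here, all three values shown are therefore of one kind, described by the limit of > 10000 nM in this assay, at which 3 of the 3 values shown sit; no measured step between any two of them exists, and nothing so far separates one compound from another. Where compound 1 stands can only be said as: at the limit, with the other two beside it.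

The next compound, compound 4 `CN(C)C(=O)/C=C/c1ccncc1-c1ccc2ccccc2c1`, differs from compound 1 in one place: dimethylamino in place of 4-methylpiperazin-1-yl on a carbonyl carbon. The shared core of compound 1 and the double-bonded chain leading to the carbonyl are kept; only the amine part of the amide changes.

With no measured step in the series and every shown value at the limit, no move beyond the scatter is expected in this assay from this change. The step from compound 1 to compound 4 is estimated as a step that the limit leaves unreadable from compound 1 to compound 4. For compound 4 the expected value in this assay is 20000 nM, with a range from 6000 nM to 60000 nM, and most likely the assay will again report only a limit.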

Compound 4, concentration for 50% growth inhibition: 7990 nM
For compound 4 the middle estimate is 2.5-fold (0.40 log units) above the measured one, within the range that was stated.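

In this assay compound 4 gives 7990 nM and is the only compound shown with a number and not a limit, which makes the amine part of the amide the first place in the series where a change leaves a readable value. Compound 1 gives > 10000 nM and that is a limit, not a number. Dimethylamino in place of 4-methylpiperazin-1-yl on a carbonyl carbon therefore gives only a floor and not a size, an at least 1.2-fold lower number from compound 1 to compound 4 (0.09 log units; that floor lies within the scatter), so the pair does not establish a real difference, and most of the series still gives no number: the limit of > 10000 nM in this assay, at which 3 of the 4 values shown sit.

Open, going by these compounds, is whether other amine parts on the same carbonyl carbon, such as diethylamino, pyrrolidin-1-yl or piperidin-1-yl, also give a number in this assay, and how such numbers would sit against that of compound 4. Also open, on these data alone, is whether a primary amide or a carboxylic acid at this carbonyl carbon, with the shared core of compound 1 kept, gives a number or stays at the limit.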